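Series notes: chloro in place of bromo

The source may report more compounds than this note shows. Statements on the series, on what has been measured and on what is new or still open speak of the compounds shown alone.

Three compounds on one shared core have numbers in a functional assay on OVCAR-3 cells (Homo sapiens) for inhibition, read by MTT assay, with a stated time of 24 h; on this read-out lower numbers stand for stronger inhibition and higher numbers for weaker inhibition. Compound 1 `CC1(C)[C@H]2CC[C@]1(C)N(Cc1cn(-c3ccccc3F)nn1)C(=O)C2` gives 300 nM, compound 2 `CC1(C)[C@H]2CC[C@]1(C)N(Cc1cn(-c3ccccc3)nn1)C(=O)C2` gives 50 nM, and compound 3 `CC1(C)[C@H]2CC[C@]1(C)N(Cc1cn(-c3ccc(Br)cc3)nn1)C(=O)C2` gives 140 nM. Compound 3 thus holds the second highest of the three numbers, and its gaps to the other two lie beyond the scatter: the series shows a 2.1-fold lower number from compound 1 to compound 3 (0.33 log units; beyond the scatter) and a 2.8-fold higher number from compound 2 to compound 3 (0.45 log units; beyond the scatter).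

The next member, compound 4 `CC1(C)[C@H]2CC[C@]1(C)N(Cc1cn(-c3ccc(Cl)cc3)nn1)C(=O)C2`, departs from compound 3 in one place: chloro in place of bromo on an aromatic carbon.

Going by the values given here, no measured step exchanges one halogen for another at this place. The nearest evidence is a 2.8-fold higher number from compound 2 to compound 3 (0.45 log units; beyond the scatter), which adds bromo to the unsubstituted phenyl and is modest. The step of a 6.0-fold lower number from compound 1 to compound 2 (0.78 log units; beyond the scatter) is also modest, but it concerns fluoro and bears less directly. Compound 4 therefore is expected to stay close to compound 3, perhaps shifted slightly towards compound 2, with no change beyond the scatter expected. The estimated step is a 1.3-fold lower number from compound 3 to compound 4 (0.10 log units; within the scatter). For compound 4 the estimated value is 110 nM, with an expected range of 50 nM to 250 nM.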

Compound 4, half-maximal inhibitory concentration: 160 nM
Beside the measured number, compound 4's estimate is 1.5-fold (0.16 log units) below it; measured number inside the range.
By their numbers in this assay, from the lowest: compound 2; then compounds 3, 4 and 1 (each within the scatter of the next, the first and the last beyond it).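

In this assay, going by these compounds alone, this is the first exchange of one halogen for another at this place, and a 1.1-fold higher number from compound 3 to compound 4 (0.06 log units; within the scatter) means that bromo and chloro cannot be told apart here. Chloro in place of hydrogen gives a 3.2-fold higher number from compound 2 to compound 4 (0.51 log units; beyond the scatter), a modest step in the same direction as a 2.8-fold higher number from compound 2 to compound 3 (0.45 log units; beyond the scatter), so both 4-halophenyl compounds stand apart from the unsubstituted phenyl of compound 2 by more than the scatter. The comparison with the 2-fluorophenyl compound also reads differently for the two halogens: a 2.1-fold lower number from compound 1 to compound 3 (0.33 log units; beyond the scatter) lies just beyond the scatter, whereas a 1.9-fold lower number from compound 1 to compound 4 (0.27 log units; within the scatter) lies within it, so compound 4 cannot be separated from compound 1 in this assay.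

No measurement at hand accounts for the gap between compound 2 and the two 4-halophenyl compounds. From the compounds shown here alone, whether methoxy, an amine or a carboxylic acid on this aromatic carbon would stay with compound 3 and compound 4 or come closer to compound 2 remains open.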